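Fluoro to hydrogen on the benzyl group of compound 1

The compounds below may be only part of what the source reports. "The series", "measured", "known", "first", "only" and "open" are said of these compounds alone.

Measured so far in an ADME assay on KB cells (Homo sapiens) for cytotoxicity; a lower number here means that less compound is needed, a higher number that more compound is needed for the effect
- compound 1 `CCOC(=O)N1[C@@H]2C=C[C@@](OC)(C(=O)c3c2cc(OC)c(OC)c3OCc2ccccc2F)N1C(=O)OCC` gives 99.7 ug/mL
- compound 2 `CCCOc1c(OC)c(OC)cc2c1C(=O)[C@]1(OC)C=C[C@H]2N(C(=O)OCC(C)C)N1C(=O)OCC(C)C` gives 299 ug/mL

Compound 1 holds the lower of the two numbers, and compound 2 lies higher, beyond the scatter. These two compounds differ in more than one place, so their gap does not isolate any single change.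

Compound 3 `CCOC(=O)N1[C@@H]2C=C[C@@](OC)(C(=O)c3c2cc(OC)c(OC)c3OCc2ccccc2)N1C(=O)OCC` is still unmeasured. It differs from compound 1 by hydrogen in place of fluoro on an aromatic carbon in going from 2-fluorobenzyl to benzyl, with hydrogen in place of fluoro on an aromatic carbon. Among the measured compounds shown here, the series holds no measured step for this change, so the expectation rests on compound 1 at 99.7 ug/mL as the closest reference. The expected change is a 1.0-fold higher number from compound 1 to compound 3 (0.00 log units; within the scatter) in this assay and stays within the scatter, with no set direction. The estimated value for compound 3 is 100 ug/mL with 45 ug/mL to 220 ug/mL as the expected span.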

Compound 3, concentration for half-maximal effect: 215 ug/mL
For compound 3 the middle estimate is 2.2-fold (0.33 log units) below the measured one; low and high end bracket the measured number.
By their numbers in this assay, from the lowest: compound 1; then compounds 3 and 2 (each within the scatter of the next).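

Hydrogen in place of fluoro on an aromatic carbon, ortho to a large group, gives in this assay a 2.2-fold higher number from compound 1 to compound 3 (0.33 log units; beyond the scatter), the first step in the series that isolates a single change. Fluoro and hydrogen are therefore not interchangeable at this place: the 2-fluorobenzyl compound 1 needs less compound for the effect than the benzyl compound 3, although the step is modest. No measurement on hand accounts for this difference.

The compounds shown leave open whether a chloro or a methyl group at the same place would give a lower or a higher number than fluoro. Also open, on these data alone, is how the benzyloxy group compares with a shorter chain, since compound 2 differs from compound 3 in more than one place.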